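From methoxymethoxy to (tert-butoxycarbonyl)amino on an aromatic carbon

This account rests on a few compounds, and the source may have more. Where it says the series, first, only, none or still open, it means among the compounds named here.

- Compound 1 `COc1ccc([C@@H]2C[C@@H]2c2cc(OC)c(OC)c(OC)c2)cc1O`: 102 nM
- Compound 2 `COCOc1cc(/C=C\c2cc(OC)c(OC)c(OC)c2)ccc1OC`: 269 nM

These two values come from a functional assay on MCF7 cells (Homo sapiens) for cytotoxicity, read by MTT assay; a higher number here means a weaker inhibitor, a lower number a stronger inhibitor. Compound 2, at 269 nM, holds the higher of the two numbers and so is the weaker inhibitor. Its gap to compound 1 lies beyond the usual scatter.

The next structure is compound 3 `COc1ccc(/C=C\c2cc(OC)c(OC)c(OC)c2)cc1NC(=O)OC(C)(C)C`, which carries (tert-butoxycarbonyl)amino in place of methoxymethoxy on an aromatic carbon. Going by the values given here, no pair of measured compounds shows this exchange, so the expectation rests on the structural change alone and remains uncertain. A move toward a higher number in this assay, beyond the scatter, is expected. The expected step is a 2.6-fold higher number from compound 2 to compound 3 (0.42 log units; beyond the scatter). For compound 3 the estimated value is 700 nM, with an expected range from 150 nM to 3500 nM.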

Compound 3, half-maximal inhibitory concentration: 3850 nM
Compound 3: the middle estimate sits 5.5-fold (0.74 log units) below what was measured; the whole stated range lies below it.
By their numbers in this assay, from the lowest: compound 1; then compound 2; then compound 3.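

In this assay the exchange of methoxymethoxy for (tert-butoxycarbonyl)amino on this aromatic carbon, ortho to a methoxy group, gives a 14-fold higher number from compound 2 to compound 3 (1.16 log units; beyond the scatter) and so counts as a large step. It is the only one-place comparison among the compounds shown, and it reveals that the number at this position responds strongly to the group placed there: the larger (tert-butoxycarbonyl)amino, which also carries a hydrogen-bond donor that methoxymethoxy lacks, goes with the weaker inhibitor. No measurement here accounts for this loss.

The compounds shown leave open whether a free amine or a small acetamide on this carbon would stand closer to compound 2 than to compound 3. They also leave open whether the nitrogen or the tert-butyl part of the entering group goes with the higher number.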